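The source may hold more compounds than are shown below. What is called first, only, known or untested is meant among the compounds shown, and "the series" means these compounds.

Compound 1, `Nc1cc(N)c2nc(-c3ccccc3)c(Oc3ccc(F)cc3)nc2c1`: 46800 nM
Compound 2, `CCOC(=O)[C@H](CCC(=O)O)NC(=O)c1ccc(CNc2nc3cc(N)cc(N)c3nc2-c2ccccc2)cc1`: < 100000 nM

Of the compounds shown here, two have been tested in a functional assay on A549 cells (Homo sapiens) for inhibition, read by sulforhodamine B assay, with a stated time of 48 h; a lower number here means a stronger inhibitor of growth, a higher number a weaker inhibitor of growth. Within the data shown here, compound 1 gives 46800 nM, which is the only actual number in the set, so compound 1 stands alone as the one compound with a measured concentration for total growth inhibition. Compound 2 gives only a limit, < 100000 nM, which does not fix its activity to a number. This is the limit of < 100000 nM in this assay, at which 1 of the 2 values shown sits. Among the measured compounds shown here, no two measured compounds differ in just one place, so nothing here tells how any single change moves the read-out.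

Compound 3, `Nc1cc(N)c2nc(-c3ccccc3)c(NCc3ccc(F)cc3)nc2c1`, has not yet been measured. It differs from compound 1 in one place: (4-fluorobenzyl)amino in place of 4-fluorophenoxy on an aromatic carbon. The shared core and the phenyl group stay the same. For the measured compounds named here, with no measured step to build on, the expected step is a 1.2-fold lower number from compound 1 to compound 3 (0.07 log units; within the scatter), a change within the usual scatter rather than a clear move in either direction. Compound 3 is therefore estimated at 40000 nM, with a range from 10000 nM to 150000 nM, and there is some chance that the assay will again report only a limit.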

Compound 3, concentration for total growth inhibition: 34700 nM
Compound 3: the middle estimate sits 1.2-fold (0.06 log units) above what was measured; low and high end bracket the measured number.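

In this assay, the change at this position gives a 1.3-fold lower number from compound 1 to compound 3 (0.13 log units; within the scatter), so the two compounds cannot be told apart. Among these compounds, this is the first single-place comparison in the set, and it concerns the aromatic carbon next to the ring nitrogen and ortho to the phenyl group. The entering (4-fluorobenzyl)amino group carries a hydrogen-bond donor that the leaving 4-fluorophenoxy group lacks, and it has nitrogen where that group has oxygen, yet this pair shows no difference in the read-out beyond the scatter.

Among the compounds shown here, compound 2 gives only a limit and differs from the other compounds in more than one place, so it adds no step to this comparison: the limit of < 100000 nM in this assay, at which 1 of the 3 values shown sits. Going by these compounds, whether a group of another kind on this same aromatic carbon, such as a methoxy group or a piperazine ring, would move the number beyond the scatter stays open, as does what happens when the fluorine on the benzyl ring is replaced by chlorine.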